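The compounds below may be only part of what the source reports. "The series", "measured", "known", "first", "only" and "open" are said of these compounds alone.

Measured compounds:
compound 1 `CCC[C@@H](CCO)Nc1nc(N)nc(C)c1Cc1ccc(CNC2CNC2)cc1OC` — > 10000 nM
compound 2 `CCC[C@@H](CO)Nc1nc(N)nc(C)c1Cc1ccc(CNC2CN(C)C2)cc1OC` — 6170 nM
compound 3 `CCC[C@@H](CO)Nc1nc(N)nc(C)c1Cc1ccc(CN(C)C)cc1OC` — 490 nM

In an assay on HEK293 cells for agonist activity at Toll-like receptor 8 (Homo sapiens) (a lower number here means that less compound is needed, a higher number that more compound is needed for the effect), compound 1 gives only a limit, > 10000 nM, which is where the limit of > 10000 nM in this assay, at which 1 of the 3 values shown sits, sits. In this assay, for the measured compounds named here, compound 2 gives 6170 nM and compound 3 gives 490 nM; the step of a 13-fold lower number from compound 2 to compound 3 (1.10 log units; beyond the scatter) is the one measured change that removes an azetidine from the benzylic amine. Compound 4 `CCC[C@@H](CCO)Nc1nc(N)nc(C)c1Cc1ccc(CNCCO)cc1OC` differs from compound 1 by 2-hydroxyethyl in place of azetidin-3-yl on an amine nitrogen. The measured step touches a related but not identical exchange, so it bears on this step only loosely. The estimate for compound 4 is 5000 nM (range 1500 nM to 20000 nM), the expected step being an at least 2.0-fold lower number from compound 1 to compound 4 (0.30 log units; that floor lies within the scatter), a moderate lowering that may still leave only a limit.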

Compound 4, half-maximal effective concentration: > 10000 nM
Compound 4 was reported as a limit; the forecaster's own chance of this, stated with the estimate: 35%; middle value at least 2.0-fold (0.30 log units) from the limit.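

In this assay compound 1 and compound 4 each give only a limit, so no step can be read between them: the limit of > 10000 nM in this assay, at which 2 of the 4 values shown sit.

The compounds shown leave open whether 2-hydroxyethyl in place of azetidin-3-yl on this amine nitrogen changes the number at all, and in which direction.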